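Propanoyl in place of isobutyl on the ring amine

This account rests on a few compounds, and the source may have more. Where it says the series, first, only, none or still open, it means among the compounds named here.

Measured so far:
compound 1 `O=C1NCCc2nc(C#Cc3ccccc3F)sc21`, 1500 nM
compound 2 `CC(C)CN1CCc2nc(C#Cc3ccccc3)sc2C1`, > 10000 nM

In an assay on HEK293 cells for positive allosteric modulation of metabotropic glutamate receptor 5 (Homo sapiens), read by FLIPR, with a stated time of 1 h (on this read-out higher numbers stand for an effect only at larger amounts of compound and lower numbers for an effect already at smaller amounts), compound 1 gives 1500 nM. Compound 2 sits at the limit of > 10000 nM in this assay, at which 1 of the 2 values shown sits, a limit of the assay rather than a number. Compound 3 `CCC(=O)N1CCc2nc(C#Cc3ccccc3)sc2C1` differs from compound 2 by propanoyl in place of isobutyl on an amine nitrogen in a ring. Within the data shown here, no measured step covers this change. Compound 3 is expected to reach a measurable value, with the step of an at least 6.6-fold lower number from compound 2 to compound 3 (0.82 log units; beyond the scatter) from the limit downward, beyond the usual scatter. The estimate for compound 3 is 1500 nM, within 300 nM to 8000 nM, guided by compound 1 which gives 1500 nM.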

Compound 3, half-maximal effective concentration: > 10000 nM
Compound 3: no number, only a limit (the forecaster's own chance of this, stated with the estimate: 25%); middle value at least 6.6-fold (0.82 log units) away from the limit.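

Compound 3 gives > 10000 nM, a limit of the assay and not a number. Compound 2 also stands at a limit, and the step between compound 2 and compound 3 cannot be read. The compounds shown leave open what propanoyl in place of isobutyl on an amine nitrogen in a ring does to the value.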